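The source may report more compounds than this note shows. Statements on the series, on what has been measured and on what is new or still open speak of the compounds shown alone.

Measured compounds:
Compound 1 `CCCCCNC(=O)/N=C(\N)NCCCc1sc(N)nc1C` gives 4.47 nM in an assay on membranes from Sf9 cells for displacement of a labelled ligand from histamine H2 receptor (Homo sapiens), read by scintillation counting, with a stated time of 60 min; a higher number here means a weaker inhibitor, a lower number a stronger inhibitor.
Compound 2 `Cc1nc(N)sc1CCCN/C(N)=N/C(=S)N[C@@H](C)c1ccccc1` gives 339 nM in this assay.
Compound 3 `CCCCCCNC(=O)/N=C(\N)Nc1cccc(-c2csc(N)n2)c1` gives 692 nM in this assay.

Among these three, compound 1 stands lowest, and its gaps to compound 2 and to compound 3 are both well beyond the scatter, so on the numbers shown it is the strongest inhibitor of the set. Compound 1 serves as the point of departure for the new compound 4 `CCCNC(=O)/N=C(\N)NCCCc1sc(N)nc1C`, which has not yet been measured in this assay.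

The change from compound 1 to compound 4 is hydrogen in place of ethyl on a saturated chain carbon, three bonds along the chain from an amide-type nitrogen. Within the data shown here, no pair of measured compounds differing in only one place is available to calibrate a shortening of this chain, so the expectation rests on the structural change alone. Because the core of compound 1 with its value of 4.47 nM is kept intact, and only the chain on the amide-type nitrogen is shortened, compound 4 is expected to show a step of a 1.8-fold higher number from compound 1 to compound 4 (0.25 log units; within the scatter), a small loss that may well fall within the scatter. Compound 4 is therefore estimated at 8 nM, with a range from 3 nM to 25 nM.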

Compound 4, inhibition constant: 105 nM
Compound 4: middle estimate off by 13-fold (1.12 log units), on the low side, and the stated range ends below it.
By their numbers in this assay, from the lowest: compound 1; then compound 4; then compound 2; then compound 3.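

Shortening pentyl to propyl, with hydrogen in place of ethyl on a saturated chain carbon, three bonds along the chain from an amide-type nitrogen, gives a 23-fold higher number from compound 1 to compound 4 (1.37 log units; beyond the scatter) in this assay. Among these compounds, this is the first step in the set that isolates a single place, since the earlier compounds differed from one another in more than one place and could not show that the length of this chain matters on the shared core. No measurement shown accounts for the size of this loss.

The compounds shown leave open whether the number rises gradually or abruptly between these two chain lengths, a question that a butyl chain on the shared core would address. They also leave open whether a longer chain, such as heptyl, would lower the number further or raise it again.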